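A few compounds are considered here, and "the series" means these few. Any claim that something is new, unique, unknown or untested is made for them only; others in the source may bear on it.

In an ADME assay on a cell-free system (plasma, Rattus norvegicus) for metabolic stability, read by LC-MS, with a stated time of 60 min, tested at 100 uM (a lower number here means that less of the compound is left, a higher number that more of the compound is left), compound 1 (`Cc1c(OCCCCOCOc2ccc(C(=O)O)cc2)ccc(C(=O)CC2CCCC2)c1O`) gives 100% and compound 2 (`Cc1c(OCCCCOc2ccc(C(=O)O)cc2F)ccc(C(=O)CC2CCCC2)c1O`) gives 97%, while compound 3 (`Cc1ccc(C(=O)O)cc1OCCCCOc1ccc(C(=O)CC2CCCC2)c(O)c1C`) gives 100% as its reading. Compound 3 is therefore level with compound 1, and compound 2 sits within the scatter of both. Compound 4 (`Cc1c(OCCCCOc2ccc(C(=O)O)c(Cl)c2)ccc(C(=O)CC2CCCC2)c1O`) has 4-carboxy-3-chlorophenyl in place of 5-carboxy-2-methylphenyl on an oxygen on a saturated carbon. Within the data shown here, earlier swaps of the group on that oxygen moved the number little (a number 3 percentage points lower from compound 1 to compound 2 (within the scatter)) and (a number 3 percentage points higher from compound 2 to compound 3 (within the scatter)) and (no change at the digits printed from compound 1 to compound 3 (within the scatter)), although no measured compound carries chlorine. No step beyond the scatter is therefore expected in this assay, and the estimated change is a number 2 percentage points lower from compound 3 to compound 4 (within the scatter). The estimate for compound 4 is 98%, with an expected range from 90% to 100%.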

Compound 4, percent of the compound remaining: 97%
Beside the measured number, compound 4's estimate is 1 percentage points above it, and the stated range covers the measured number.
By their numbers in this assay, from the lowest: compounds 2, 4, 1 and 3 (each within the scatter of the next).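

In this assay, 4-carboxy-3-chlorophenyl brings the first chlorine to this place on the oxygen, and its steps all stay within the scatter (a number 3 percentage points lower from compound 3 to compound 4 (within the scatter); no change at the digits printed from compound 2 to compound 4 (within the scatter); a number 3 percentage points lower from compound 1 to compound 4 (within the scatter)). So a chlorine-bearing group joins the fluorine-bearing and methyl-bearing groups here with no step beyond the scatter. Nothing measured here explains this.

Every compound shown carries a carboxylic acid on this group, so it stays open whether an amide or a tetrazole in its place would give a step beyond the scatter.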